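Bromo on the phenyl of compound 3: an expected outcome

The source may report more compounds than this note shows. Statements on the series, on what has been measured and on what is new or still open speak of the compounds shown alone.

Compounds measured in a functional assay on DU-145 cells (Homo sapiens) for cytotoxicity, read by MTT assay; on this read-out lower numbers stand for stronger inhibition and higher numbers for weaker inhibition:
compound 1, `CC(O)(CS(=O)(=O)c1ccccc1)c1nc(-c2ccc(Cl)cc2)no1`, > 100000 nM
compound 2, `CC(O)(CSc1ccc(F)cc1)c1nc(-c2ccc([N+](=O)[O-])c(C(F)(F)F)c2)no1`, 5100 nM
compound 3, `CC(O)(CS(=O)(=O)c1ccccc1)c1nc(-c2ccccc2)no1`, > 100000 nM

Compound 3 stands at the limit of this assay: its value of > 100000 nM is a limit, not a number. Compound 1 likewise gives only a limit, > 100000 nM. Among the three measured compounds, only compound 2 gives a number, 5100 nM, and compound 2 differs from compound 3 in more than one place, so no single step links them. Within the data shown here, the one measured step, a step that the two limits leave unreadable from compound 1 to compound 3, is a change of hydrogen in place of chloro on an aromatic carbon; the limit of > 100000 nM in this assay, at which 2 of the 3 values shown sit, leaves its size unreadable.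

Compound 4, `CC(O)(CS(=O)(=O)c1ccc(Br)cc1)c1nc(-c2ccccc2)no1`, differs from compound 3 by bromo in place of hydrogen on an aromatic carbon. Among the measured compounds shown here, no measured step concerns bromo on this ring, and the step from compound 1 to compound 3 tells nothing of size, so no direction can be drawn from the data. Compound 4 is therefore expected to remain near the limit, and its value in this assay is estimated at 100000 nM, within a range of 30000 nM to 300000 nM. This estimate for compound 4 corresponds to an expected step of a number no higher from compound 3 to compound 4 (the limit leaves the size open), none beyond the scatter.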

Compound 4, half-maximal inhibitory concentration: > 100000 nM
Compound 4: no number, only a limit; the forecaster's own chance of this, stated with the estimate: 75%; the middle value sits exactly at the limit.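

The step between compound 3 and compound 4 cannot be read, because both give only a limit in this assay: the limit of > 100000 nM in this assay, at which 3 of the 4 values shown sit.

The compounds shown leave open what size, if any, the change from phenyl to 4-bromophenyl has on this core in this assay.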